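A few compounds are considered here, and "the series" means these few. Any claim that something is new, unique, unknown or untested is made for them only; others in the source may bear on it.

Working notes on the series. Compound 1 `Cc1ccc(Cn2ccc3nc(-c4ccccc4)nc-3c2)cc1`, compound 2 `COc1cccc(Cn2ccc3nc(-c4ccccc4)nc-3c2)c1` and compound 3 `Brc1ccccc1Cn1ccc2nc(-c3ccccc3)nc-2c1` share one core and differ only in the group on the saturated chain carbon bound to an aromatic nitrogen. In an ADME assay on MDBK cells (Bos taurus) for cytotoxicity (a lower number here means that less compound is tolerated, a higher number that more compound is tolerated), compound 1 gives > 100000 nM, which is a limit of the assay and not a number. Compound 2 gives > 100000 nM in this assay, again a limit. Compound 3 stands at > 100000 nM in this assay, also a limit, so its position on the scale is known only as that limit. The steps a step that the two limits leave unreadable from compound 1 to compound 2, a step that the two limits leave unreadable from compound 1 to compound 3 and a step that the two limits leave unreadable from compound 2 to compound 3 cannot be sized, since (the limit of > 100000 nM in this assay, at which 3 of the 3 values shown sit). Compound 4 `Ic1ccc(Cn2ccc3nc(-c4ccccc4)nc-3c2)cc1` is not yet measured; it differs from compound 3 by 4-iodophenyl in place of 2-bromophenyl on a saturated chain carbon bound to an aromatic nitrogen. Among the measured compounds shown here, no measured step bears on this change with a readable size, and every measured value so far sits at the limit. The step that the limit leaves unreadable from compound 3 to compound 4 is therefore expected to be none beyond the scatter. Compound 4 is estimated at 150000 nM in this assay, with a range from 60000 nM to 400000 nM, most likely reported again as a limit.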

Compound 4, half-maximal cytotoxic concentration: 22000 nM
The estimate for compound 4 lay 6.8-fold (0.83 log units) above the measured number; the measured number lies below the stated range.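

The group on the saturated chain carbon bound to an aromatic nitrogen can change the read-out in this assay: 4-iodophenyl in place of 2-bromophenyl gives an at least 4.5-fold lower number from compound 3 to compound 4 (0.65 log units; beyond the scatter). The same group also separates from the other two, with an at least 4.5-fold lower number from compound 2 to compound 4 (0.65 log units; beyond the scatter) for 4-iodophenyl in place of 3-methoxyphenyl and an at least 4.5-fold lower number from compound 1 to compound 4 (0.65 log units; beyond the scatter) for iodo in place of methyl on an aromatic carbon. The steps among compound 1, compound 2 and compound 3 remain unreadable, and these three new sizes are only minimum sizes, because each starts from a limit: the limit of > 100000 nM in this assay, at which 3 of the 4 values shown sit.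

The compounds shown do not separate the change of halogen from the change of ring position, which a 4-bromophenyl group could address. From the compounds shown here alone, how an amine or a carboxylic acid on that phenyl ring would read in this assay also remains open.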